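Replacing trifluoromethyl with methoxyphenyl: a small expected change

The compounds below may be only part of what the source reports. "The series", "measured", "known", "first", "only" and "open" are said of these compounds alone.

Of the compounds shown here, three sharing one core have been tested in an ADME assay on A549 cells (Homo sapiens) for cytotoxicity, read by CellTiter-Glo; a higher number here means that more compound is tolerated, a lower number that less compound is tolerated. Compound 2 `Cc1c(Cc2ccc(F)cc2Cl)c(=O)oc2cc(OCC(O)CN3CCC(C(N)=O)CC3)ccc12` gives 90800 nM, and compound 3 `Cc1c(Cc2ccc(C(F)(F)F)cc2)c(=O)oc2cc(OCC(O)CN3CCC(C(N)=O)CC3)ccc12` gives 89300 nM. For compound 1 `Cc1cc(F)ccc1Cc1c(C)c2ccc(OCC(O)CN3CCC(C(N)=O)CC3)cc2oc1=O` the reading is a limit of the assay, > 100000 nM, which is the limit of > 100000 nM in this assay, at which 1 of the 3 values shown sits. Among the two plain numbers compound 3 holds the lower one, with compound 2 nearest at a 1.0-fold lower number from compound 2 to compound 3 (0.01 log units; within the scatter), a gap within the scatter. Compound 4 `COc1ccccc1-c1ccc(Cc2c(C)c3ccc(OCC(O)CN4CCC(C(N)=O)CC4)cc3oc2=O)cc1` has not been measured; it carries 2-methoxyphenyl in place of trifluoromethyl on an aromatic carbon. The earlier steps shown here an at least 1.1-fold lower number from compound 1 to compound 3 (0.04 log units; that floor lies within the scatter) and a 1.0-fold lower number from compound 2 to compound 3 (0.01 log units; within the scatter), which also altered that part of the molecule, hardly moved this assay, so no step beyond the scatter is expected, a 1.1-fold lower number from compound 3 to compound 4 (0.02 log units; within the scatter). Compound 4 is estimated at 85000 nM, ranging from 40000 nM to 180000 nM.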

Compound 4, half-maximal cytotoxic concentration: 91600 nM
For compound 4 the middle estimate is 1.1-fold (0.03 log units) below the measured one; low and high end bracket the measured number.
By their numbers in this assay, from the lowest: compounds 3, 2 and 4 (each within the scatter of the next). At a limit, above all of these: compound 1.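

Earlier steps only exchanged substituents on the phenyl ring, whereas here trifluoromethyl, with 4 heavy atoms, gives way to 2-methoxyphenyl, with 8 heavy atoms, a further six-membered aromatic ring and a hydrogen-bond acceptor, and this assay gives a 1.0-fold higher number from compound 3 to compound 4 (0.01 log units; within the scatter). This aromatic carbon, para to a large group, therefore carries a much larger group with no step beyond the scatter. Compound 1 stands at a limit of the assay: the limit of > 100000 nM in this assay, at which 1 of the 4 values shown sits.

From the compounds shown here alone, what an amine or a carboxylic acid on this aromatic carbon would do remains open.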